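Amino in place of dimethylamino: a small step expected

The source may report more compounds than this note shows. Statements on the series, on what has been measured and on what is new or still open speak of the compounds shown alone.

Three compounds share one core and differ only in the two groups on the six-membered aromatic ring. In a functional assay on Raji cells (Homo sapiens) (a higher number here means a weaker inhibitor, a lower number a stronger inhibitor), compound 1 `CN(C)c1nc(N)c2ncn([C@@H]3C[C@@H](O)[C@H](CO)O3)c2n1` gives 125 uM, compound 2 `CSc1nc(SC)c2ncn([C@@H]3C[C@@H](O)[C@H](CO)O3)c2n1` gives 170 uM, and compound 3 `CSc1nc(N(C)C)c2ncn([C@@H]3C[C@@H](O)[C@H](CO)O3)c2n1` gives 233 uM. Compound 3 sits within the usual scatter of both others: the number of compound 2 lies nearer, that of compound 1 further, and neither gap is beyond the scatter. Compound 4 `CSc1nc(N)c2ncn([C@@H]3C[C@@H](O)[C@H](CO)O3)c2n1` is not yet measured; it differs from compound 3 by amino in place of dimethylamino on an aromatic carbon. Going by the values given here, the one measured step at this position, a 1.4-fold higher number from compound 2 to compound 3 (0.14 log units; within the scatter), gives no sign of a real change, and no measured step exchanges dimethylamino for amino there. The step from compound 3 to compound 4 is therefore expected to stay small, a 1.2-fold lower number from compound 3 to compound 4 (0.07 log units; within the scatter), with no clear direction. Compound 4 is estimated at 200 uM, between 100 uM and 400 uM, in this assay.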

Compound 4, concentration for 50% inhibition: 107 uM
Compound 4: the middle estimate sits 1.9-fold (0.27 log units) above what was measured, and the stated range covers the measured number.
By their numbers in this assay, from the lowest: compounds 4, 1, 2 and 3 (each within the scatter of the next, the first and the last beyond it).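

In this assay, going by these compounds alone, amino in place of dimethylamino gives a 2.2-fold lower number from compound 3 to compound 4 (0.34 log units; beyond the scatter) and is the only one of these steps beyond the scatter, though it is modest. Amino in place of methylsulfanyl gives a 1.6-fold lower number from compound 2 to compound 4 (0.20 log units; within the scatter) and stays within the scatter, as does methylsulfanyl in place of dimethylamino with amino held in place, which gives a 1.2-fold lower number from compound 1 to compound 4 (0.07 log units; within the scatter). Exchanging these two groups changes little with either partner group: the same change on two cores in this assay, a 1.4-fold higher number (0.14 log units; within the scatter) from compound 2 to compound 3 and a 1.2-fold higher number (0.07 log units; within the scatter) from compound 4 to compound 1, 1.2-fold (0.07 log units) apart, within the scatter of two such steps.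

On these data alone, whether a longer chain such as ethylamino or a ring amine such as morpholine would lower the number further remains open.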